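This account rests on a few compounds, and the source may have more. Where it says the series, first, only, none or still open, it means among the compounds named here.

Measured in a functional assay on A549 cells (Homo sapiens) for cytotoxicity, read by MTT assay, with a stated time of 48 h; a lower number here means a stronger inhibitor, a higher number a weaker inhibitor:
- compound 1 `O=C(/C=C/c1cccc(F)c1)Nc1ccc(CC2=CC(=O)OC2)cc1`: > 50000 nM, a limit and not a number
- compound 2 `O=C(/C=C/c1ccccc1F)Nc1ccc(CC2=CC(=O)OC2)cc1`: 40000 nM

Compound 3 `C=C1OC(=O)C=C1Cc1ccc(NC(=O)/C=C/c2cccc(F)c2)cc1` is not yet measured. Compound 1 offers no number as a starting point, only (the limit of > 50000 nM in this assay, at which 1 of the 2 values shown sits). Compound 3 keeps the core of compound 1 and changes one group: a group of 7 heavy atoms (5 carbon, 2 oxygen; one five-membered non-aromatic ring with 1 hetero atom) in place of a group of 6 heavy atoms (4 carbon, 2 oxygen; one five-membered non-aromatic ring with 1 hetero atom), on a saturated chain carbon bound to an aromatic carbon. Among the measured compounds shown here, the single measured step, an at least 1.2-fold lower number from compound 1 to compound 2 (0.09 log units; that floor lies within the scatter), stays within the scatter and concerns the fluorophenyl group, so no measured step bears directly on this replacement. For the measured compounds named here, the only guide is that compound 2 gives 40000 nM, which keeps the expectation for the series in the same high range. In this assay, a modest move to a lower number is expected, with a real chance of another limit. The expected step is an at least 2.0-fold lower number from compound 1 to compound 3 (0.30 log units; that floor lies within the scatter). For compound 3 the estimated value is 25000 nM, with an expected range of 8000 nM to 60000 nM.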

Compound 3, half-maximal inhibitory concentration: 35200 nM
The estimate for compound 3 lay 1.4-fold (0.15 log units) below the measured number; the range from low to high includes it.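

In this assay, among the compounds shown here, this is the first reading of a change on the saturated chain carbon bound to an aromatic carbon: the group of 7 heavy atoms, with 3 double bonds outside aromatic rings, replaces the group of 6 heavy atoms, with 2, and gives an at least 1.4-fold lower number from compound 1 to compound 3 (0.15 log units; that floor lies within the scatter). Compound 3 also gives the series a number rather than a limit among the 3-fluorophenyl compounds, at 35200 nM. The reading for compound 1 is a limit and not a number, so the step is only a floor: the limit of > 50000 nM in this assay, at which 1 of the 3 values shown sits.

On these data alone, the true size of this step stays open, as does whether any replacement at this place can move the number beyond the scatter. As far as these compounds go, how an amine or a carboxylic acid would read at this place is also open.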